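Methyl to methoxy on the biaryl of the cyclopropanecarboxamide series

The source may hold more compounds than are shown below. What is called first, only, known or untested is meant among the compounds shown, and "the series" means these compounds.

Measured so far:
compound 1 `CC(C)C[C@H](N)CN(C(=O)[C@@H]1C[C@H]1c1ccccc1)c1ccc(-c2ccsc2)cc1`, 1200 nM
compound 2 `Cc1ccccc1-c1ccc(N(C[C@@H](N)CC(C)C)C(=O)[C@@H]2C[C@H]2c2ccccc2)cc1`, 3400 nM

In a functional assay for agonist activity at G protein-coupled receptor 88 (Homo sapiens), read by HTRF and cAMP accumulation (on this read-out higher numbers stand for an effect only at larger amounts of compound and lower numbers for an effect already at smaller amounts), compound 2 stands at the highest of the two numbers; its nearest neighbour is compound 1, reached by a 2.8-fold higher number from compound 1 to compound 2 (0.45 log units; beyond the scatter), a modest step, the only one measured.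

Compound 3 `COc1ccccc1-c1ccc(N(C[C@@H](N)CC(C)C)C(=O)[C@@H]2C[C@H]2c2ccccc2)cc1` differs from compound 2 in one place: methoxy in place of methyl on an aromatic carbon, on an aromatic carbon of a six-membered aromatic ring of carbon only, ortho to a large group. Among the compounds with values here, the one step that bears on this position, from compound 1 to compound 2, swapped the whole aryl group and moved the number only modestly. A smaller exchange at the same place is expected to move it less, most likely within the scatter, with no direction favoured.

Compound 3 is therefore expected near 3000 nM in this assay, between 1200 nM and 7500 nM, an expected step of a 1.1-fold lower number from compound 2 to compound 3 (0.05 log units; within the scatter).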

Compound 3, half-maximal effective concentration: 3200 nM
Compound 3: middle estimate off by 1.1-fold (0.03 log units), on the low side; measured number inside the range.
By their numbers in this assay, from the lowest: compound 1; then compounds 3 and 2 (each within the scatter of the next).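

In this assay the exchange of 2-methylphenyl for 2-methoxyphenyl gives a 1.1-fold lower number from compound 2 to compound 3 (0.03 log units; within the scatter) and so leaves the two groups indistinguishable at this position, even with the added oxygen and its hydrogen-bond acceptor. Against thiophen-3-yl the new group gives a 2.7-fold higher number from compound 1 to compound 3 (0.43 log units; beyond the scatter) and thus resembles the earlier 2.8-fold higher number from compound 1 to compound 2 (0.45 log units; beyond the scatter) in this series, so the gap to compound 1 is not confined to the methyl-bearing phenyl. Nothing at hand accounts for either result.

Open, going by these compounds, is whether the number at this position tracks the substituent on the phenyl at all, which a plain phenyl would help to settle. Also open, on these data alone, is how a hydroxyl, an amine or a carboxylic acid in place of methoxy would read on this ring.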